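Aryl methyl removal on a quinoline ether triazole series

A few compounds are considered here, and "the series" means these few. Any claim that something is new, unique, unknown or untested is made for them only; others in the source may bear on it.

Measured compounds in a functional assay on A549 cells (Homo sapiens) for cytotoxicity, read by MTT assay, with a stated time of 72 h; a lower number here means a stronger inhibitor, a higher number a weaker inhibitor:
compound 1 `COc1cc2c(Oc3ccc(NC(=O)c4nnn(-c5ccccc5C)c4C)cc3F)ccnc2cc1OCCCN1CCCC1` gives 380 nM;
compound 2 `COc1cc2c(Oc3ccc(NC(=O)c4nnn(-c5ccccc5)c4C)cc3F)ccnc2cc1OCCCN1CCCC1` gives 90 nM;
compound 3 `COc1cc2c(Oc3ccc(NC(=O)c4nnn(-c5ccccc5C)c4C)cc3F)ccnc2cc1OCCCN1CCCCC1` gives 330 nM.

Compound 3 stands second highest of the three numbers in this assay. Its nearest neighbour is compound 1, which differs only in the amine at the end of the chain, and the step of a 1.2-fold lower number from compound 1 to compound 3 (0.06 log units; within the scatter) lies within the scatter. The furthest is compound 2, and the gap between compound 3 and compound 2 is beyond the scatter.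

Compound 4 `COc1cc2c(Oc3ccc(NC(=O)c4nnn(-c5ccccc5)c4C)cc3F)ccnc2cc1OCCCN1CCCCC1` is not yet measured. It differs from compound 3 by hydrogen in place of methyl on an aromatic carbon. The same change is seen once already in this set, from compound 1 to compound 2, where the step of a 4.2-fold lower number from compound 1 to compound 2 (0.63 log units; beyond the scatter) was beyond the scatter, a modest gain. Since the chain-end amine change, a 1.2-fold lower number from compound 1 to compound 3 (0.06 log units; within the scatter), made no difference beyond the scatter, the removal of the aryl methyl is taken as the step that matters here, and a gain of similar size is expected in this assay for compound 4.

The expected step is a 3.9-fold lower number from compound 3 to compound 4 (0.59 log units; beyond the scatter). For compound 4 the estimate in this assay is 85 nM, with a range from 40 nM to 180 nM.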

Compound 4, half-maximal inhibitory concentration: 100 nM
The estimate for compound 4 lay 1.2-fold (0.07 log units) below the measured number, and the stated range covers the measured number.
By their numbers in this assay, from the lowest: compounds 2 and 4 (each within the scatter of the next); then compounds 3 and 1 (each within the scatter of the next).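

In this assay, the change from 2-methylphenyl to phenyl now has a second reading, on the core carrying the piperidin-1-yl chain end, with a 3.3-fold lower number from compound 3 to compound 4 (0.52 log units; beyond the scatter), so the gain no longer rests on a single pair and the two readings agree: the same change on two cores in this assay, a 4.2-fold lower number (0.63 log units; beyond the scatter) from compound 1 to compound 2 and a 3.3-fold lower number (0.52 log units; beyond the scatter) from compound 3 to compound 4, 1.3-fold (0.11 log units) apart, within the scatter of two such steps. The chain-end amine also has a second reading, now on the phenyl series, where a 1.1-fold higher number from compound 2 to compound 4 (0.05 log units; within the scatter) again leaves the number within the scatter: the same change on two cores in this assay, a 1.2-fold lower number (0.06 log units; within the scatter) from compound 1 to compound 3 and a 1.1-fold higher number (0.05 log units; within the scatter) from compound 2 to compound 4, 1.3-fold (0.11 log units) apart, within the scatter of two such steps. Across these four compounds, the two changes therefore read as independent of each other, with the methyl on the aromatic carbon, ortho to a large group, separating the numbers and the piperidin-1-yl to pyrrolidin-1-yl swap not doing so.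

From the compounds shown here alone, only hydrogen and methyl appear at this place, so it stays open whether a chlorine, a methoxy or a trifluoromethyl group on the same carbon would read like the methyl or like the hydrogen. Also open, going by these compounds, are the effects of a morpholine or a dimethylamino group at the chain end, or of a longer chain, in this assay.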